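The source may hold more compounds than are shown below. What is called first, only, known or untested is meant among the compounds shown, and "the series" means these compounds.

Measured in an in vivo ADME assay on the whole organism (strain Sprague-Dawley) for pharmacokinetics, with Rattus norvegicus as the target, at a dose of 5 mg/kg by the intravenous route; on this read-out lower numbers stand for slow clearance and higher numbers for fast clearance:
- Compound 1 `CC(C)(C)CCC1(NCc2ccc3ccccc3c2)C(=O)C(C2=NS(=O)(=O)c3cc(NS(C)(=O)=O)ccc3N2)=C(O)c2ccccc21`: 23.3 mL/min/kg
- Compound 2 `COc1ccccc1CNC1(CCC(C)(C)C)C(=O)C(C2=NS(=O)(=O)c3cc(NS(C)(=O)=O)ccc3N2)=C(O)c2ccccc21`: 25 mL/min/kg

Compound 2 cannot be told apart from compound 1 on these numbers, since their values lie within the scatter of each other. Compound 3 `Cc1cccc(CNC2(CCC(C)(C)C)C(=O)C(C3=NS(=O)(=O)c4cc(NS(C)(=O)=O)ccc4N3)=C(O)c3ccccc32)n1` carries 6-methylpyridin-2-yl in place of 2-methoxyphenyl on a saturated chain carbon bound to an amine nitrogen. Among the compounds with values here, one measured step bears on this change, the exchange at the same place that gave a 1.1-fold higher number from compound 1 to compound 2 (0.03 log units; within the scatter). Within the data shown here, neither measured compound has a ring with a hetero atom at this place, so the data offer no direct precedent and the range stays wide. No change beyond the scatter is expected in either direction, and the expected step is a 1.1-fold lower number from compound 2 to compound 3 (0.06 log units; within the scatter). For compound 3 the estimated clearance is 22 mL/min/kg, with an expected range of 11 mL/min/kg to 43 mL/min/kg.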

Compound 3, clearance: 28.3 mL/min/kg
The estimate for compound 3 lay 1.3-fold (0.11 log units) below the measured number, within the range that was stated.
By their numbers in this assay, from the lowest: compounds 1, 2 and 3 (each within the scatter of the next).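

In this assay the exchange gave a 1.1-fold higher number from compound 2 to compound 3 (0.05 log units; within the scatter) and so shows that 6-methylpyridin-2-yl, a six-membered aromatic ring with a hetero atom, can sit on a saturated chain carbon bound to an amine nitrogen with no change in clearance beyond the scatter. Set against naphthalen-2-yl, the same group gave a 1.2-fold higher number from compound 1 to compound 3 (0.08 log units; within the scatter) and so the three aromatic groups seen at this place cannot be told apart on this read-out. Nothing measured here accounts for this result.

The compounds leave open whether an amine or a carboxylic acid at this place, or a longer chain carrying the ring, would take clearance beyond the scatter. All three share the rest of the core, so this reading holds for this one place only.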